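A few compounds are considered here, and "the series" means these few. Any claim that something is new, unique, unknown or untested is made for them only; others in the source may bear on it.

Compound 1 `COC1=C(OC)[C@H](O)[C@H](C/C=C(\C)CC/C=C(\C)C[C@@H]2C[C@@H](C)C(=O)O2)[C@@H](C)C1=O` is the point of departure. Among the measured compounds shown here, in a functional assay on A549 cells (Homo sapiens) for inhibition, read by sulforhodamine B assay, with a stated time of 48 h (a lower number here means a stronger inhibitor of growth, a higher number a weaker inhibitor of growth), compound 1 gives 14100 nM, the only actual number among the three measured compounds, because the two others are recorded as the limit of > 30000 nM in this assay, at which 2 of the 3 values shown sit. Compound 2 `COC1=C[C@H](O)[C@H](C/C=C(\C)CC/C=C(\C)C[C@@H]2C[C@@H](C)C(=O)O2)[C@@H](C)C1=O` reaches only the limit of > 30000 nM in this assay. Compound 3 `COC1=CC(=O)C(C/C=C(\C)CC/C=C(\C)CCC=C(C)C)=C(C)C1=O` likewise stops at the limit of > 30000 nM. For the measured compounds named here, the single step between compounds that differ in one place, an at least 2.1-fold higher number from compound 1 to compound 2 (0.32 log units; beyond the scatter), marks compound 1 as the stronger of that pair.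

Compound 4 `COC1=C(OC)[C@H](O)[C@H](C/C=C(\C)CC/C=C(\C)C[C@H](O)C=C(C)C)[C@@H](C)C1=O` has not yet been measured in this assay. It differs from compound 1 by a group of 6 heavy atoms (5 carbon, 1 oxygen; no ring) in place of a group of 7 heavy atoms (5 carbon, 2 oxygen; one five-membered non-aromatic ring with 1 hetero atom), on a saturated chain carbon bound to a double-bonded chain carbon. Going by the values given here, no measured step bears on this part of the molecule: the step from compound 1 to compound 2 concerns the methoxy on the ring, and compound 3 differs from compound 1 in more than one place, so its value cannot be tied to the chain terminus alone. With nothing to anchor a direction, the step from compound 1 to compound 4 is expected to be a 1.4-fold higher number from compound 1 to compound 4 (0.15 log units; within the scatter), not known to lie beyond the scatter. The estimate for compound 4 is therefore 20000 nM, expected to fall between 7000 nM and 50000 nM.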

Compound 4, concentration for 50% growth inhibition: 9600 nM
The estimate for compound 4 lay 2.1-fold (0.32 log units) above the measured number; the range from low to high includes it.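

In this assay, exchanging the group that holds the five-membered non-aromatic ring for 1-hydroxy-3-methylbut-2-en-1-yl, on a saturated chain carbon bound to a double-bonded chain carbon, gives a 1.5-fold lower number from compound 1 to compound 4 (0.17 log units; within the scatter). Among the compounds shown here, this is the first reading that can be tied to the chain terminus alone, since the only earlier step concerned the methoxy on the ring and compound 3 differs from compound 1 in more than one place. It shows that, on the shared core, the ring at this terminus can give way to an open group without a difference beyond the scatter, so compound 1 and compound 4 cannot be told apart in growth inhibition.

Going by these compounds, whether an amine, a carboxylic acid or a longer chain in place of 1-hydroxy-3-methylbut-2-en-1-yl would move the number beyond the scatter stays open, as does the share of the hydroxy group itself in the result for compound 4. The wider comparison also remains thin, as the entries for compound 2 and compound 3 are limits and not numbers: the limit of > 30000 nM in this assay, at which 2 of the 4 values shown sit.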